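This account rests on a few compounds, and the source may have more. Where it says the series, first, only, none or still open, it means among the compounds named here.

Measured compounds:
- compound 1 `CN(C[C@H]1Cc2c(cccc2N2CCN(Cc3ccccn3)CC2)CN1)[C@H]1CCCc2cccnc21` gives 4.2% in an ADME assay on microsomes from liver (Homo sapiens) for metabolic stability, read by LC-MS, with a stated time of 10 min; a lower number here means that less of the compound is left, a higher number that more of the compound is left
- compound 2 `CCCN(C[C@H]1Cc2c(cccc2N2CCNCC2)CN1)[C@H]1CCCc2cccnc21` gives 100% in this assay
- compound 3 `Cc1cnc2c(c1)CCC[C@@H]2N(C)C[C@H]1Cc2c(cccc2N2CCNCC2)CN1` gives 47.8% in this assay

Compound 2 stands highest of the three numbers in this assay; the nearest is compound 3, whose number lies beyond the scatter below it, and the furthest is compound 1, further still below. Among the measured compounds shown here, no pair of these differs in one place only, so no single step has been measured.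

Compound 4 `c1cnc2c(c1)CCC[C@@H]2N(CC1CCCCC1)C[C@H]1Cc2c(cccc2N2CCNCC2)CN1` remains to be measured. It differs from compound 2 as follows: cyclohexyl in place of ethyl on a saturated chain carbon bound to an amine nitrogen. For the measured compounds named here, no measured step covers this kind of change, so the expectation rests on compound 2 alone: a downward step in this assay is expected, likely beyond the scatter but not large. Compound 4 is estimated at 65% (range 25% to 100%), an expected step of a number 35 percentage points lower from compound 2 to compound 4 (beyond the scatter).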

Compound 4, percent of the compound remaining: 81.6%
Estimate against measurement, compound 4: 16.6 percentage points below; low and high end bracket the measured number.
By their numbers in this assay, from the lowest: compound 1; then compound 3; then compound 4; then compound 2.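

Cyclohexyl in place of ethyl on a saturated chain carbon bound to an amine nitrogen is the first single change measured in this series, and in this assay it gives a number 18.4 percentage points lower from compound 2 to compound 4 (beyond the scatter) as a modest step. At this position, the six-membered carbon ring therefore costs only part of the stability scale. No measurement at hand explains the step. From the compounds shown here alone, whether the step follows the added carbons or the ring itself remains open. Butyl or cyclopropyl at the same place would help separate the two.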